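The compounds below may be only part of what the source reports. "The series", "measured", "known", "first", "only" and "open" are said of these compounds alone.

Of the compounds shown here, three have been measured in an assay on a protein complex (K562 cells) for inhibition of integrin alpha-5/beta-1 (Homo sapiens), with stated times of 30 min and 1 h; a higher number here means a weaker inhibitor, a lower number a stronger inhibitor. Compound 1, with the structure `CCCN(C(=O)CC(=O)O)C1=C(C)CC(c2ccccc2)N([C@@H](C)c2ccc(N)cc2)C1=O`, gives 57 nM. Compound 2, with the structure `C/C=C(\C(=O)NCC(=O)O)C(NCc1ccc(NC(=O)CN)cc1)C(C)C`, gives 170 nM. Compound 3, with the structure `C/C=C(\C(=O)O)C(NCc1ccc(N)cc1)C(C)C`, gives 9800 nM and thus carries the highest number of the three; its nearest neighbour is compound 2, and the gap to that compound, like the larger gap to compound 1, lies beyond the usual scatter of repeated measurements. Compound 3 is therefore the weakest inhibitor of the three.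

The unmeasured compound 4 has the structure `C/C=C(\C(=O)O)C(NCc1ccc(N)cc1)C1CCCCC1`. It differs from compound 3 in one place: cyclohexyl in place of isopropyl on a saturated chain carbon bound to an amine nitrogen and a double-bonded chain carbon. The shared remainder of the molecule, including the acid and the amine-bearing ring, is unchanged.

Going by the values given here, no pair of measured compounds shows what this exchange does in this assay, so the expectation rests on the change alone. Because compound 3 gives 9800 nM, the starting point is already a high number. Compound 4 is expected to move only modestly, by about a 1.6-fold lower number from compound 3 to compound 4 (0.21 log units; within the scatter), with a small decrease in number slightly more likely than an increase, and a result within the scatter also possible. The estimate for compound 4 is 6000 nM, with a range from 2000 nM to 20000 nM.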

Compound 4, half-maximal inhibitory concentration: 2100 nM
Compound 4: the middle estimate sits 2.9-fold (0.46 log units) above what was measured; low and high end bracket the measured number.
By their numbers in this assay, from the lowest: compound 1; then compound 2; then compound 4; then compound 3.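

Cyclohexyl in place of isopropyl on a saturated chain carbon bound to an amine nitrogen and a double-bonded chain carbon brings a 4.7-fold lower number from compound 3 to compound 4 (0.67 log units; beyond the scatter) in this assay and this step lies beyond the scatter, so the number at this position depends on the group it carries. Cyclohexyl has 6 heavy atoms and a ring where isopropyl has 3 heavy atoms and no ring, and neither group has hydrogen-bond donors, hydrogen-bond acceptors or a net charge, so the lower number came with an exchange of carbon for carbon and no new group able to take part in hydrogen bonding. Nothing measured here explains why the number falls, and the reason for the step stays unknown.

This single exchange changes the atom count and adds a ring together, so it cannot show which of the two matters; a straight hexyl chain or a cyclopentyl ring at the same place would begin to separate them. As far as these compounds go, it also remains open whether the same exchange would lower the number in a compound that carries the longer parts seen in compound 2.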